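A few compounds are considered here, and "the series" means these few. Any claim that something is new, unique, unknown or untested is made for them only; others in the source may bear on it.

Values in a functional assay on HT-29 cells (Homo sapiens) for inhibition, read by MTT assay, with a stated time of 72 h; on this read-out higher numbers stand for weaker inhibition of growth and lower numbers for stronger inhibition of growth:
Compound 1, `O=S(=O)(NCCCNCc1ccccc1Cl)c1cc(C(F)(F)F)cc(C(F)(F)F)c1`: 20000 nM
Compound 2, `O=S(=O)(NCCCNCc1ccc(Cl)c(Cl)c1)c1cc(C(F)(F)F)cc(C(F)(F)F)c1`: 4700 nM
Compound 3, `O=S(=O)(NCCCNCc1cccc2ccccc12)c1cc(C(F)(F)F)cc(C(F)(F)F)c1`: 2600 nM

Compound 2 stands second highest of the three numbers in this assay; the step of a 1.8-fold lower number from compound 2 to compound 3 (0.26 log units; within the scatter) lies within the scatter, while a 4.3-fold lower number from compound 1 to compound 2 (0.63 log units; beyond the scatter) lies beyond it. Compound 4, `COc1ccccc1CNCCCNS(=O)(=O)c1cc(C(F)(F)F)cc(C(F)(F)F)c1`, differs from compound 2 as follows: 2-methoxyphenyl in place of 3,4-dichlorophenyl on a saturated chain carbon bound to an amine nitrogen. Among the compounds with values here, no measured step exchanges 3,4-dichlorophenyl for 2-methoxyphenyl. Within the data shown here, the nearest precedent is compound 1 with 2-chlorophenyl on the saturated chain carbon bound to an amine nitrogen, where a 4.3-fold lower number from compound 1 to compound 2 (0.63 log units; beyond the scatter) shows 3,4-dichlorophenyl giving the lower number. A change back in the direction of compound 1 is therefore expected to give a higher number in this assay, a step of about a 2.6-fold higher number from compound 2 to compound 4 (0.41 log units; beyond the scatter). Compound 4 is estimated at 12000 nM, range 4000 nM to 35000 nM.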

Compound 4, concentration for 50% growth inhibition: 12000 nM
Estimate against measurement, compound 4: no gap at the digits printed; measured number inside the range.
By their numbers in this assay, from the lowest: compounds 3 and 2 (each within the scatter of the next); then compounds 4 and 1 (each within the scatter of the next).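

In this assay, methoxy in place of chloro on an aromatic carbon gives no resolved change, a 1.7-fold lower number from compound 1 to compound 4 (0.22 log units; within the scatter), so compound 1 and compound 4 cannot be told apart. 2-Methoxyphenyl gives a higher number than 3,4-dichlorophenyl, a 2.6-fold higher number from compound 2 to compound 4 (0.41 log units; beyond the scatter), and than naphthalen-1-yl, a 4.6-fold higher number from compound 3 to compound 4 (0.66 log units; beyond the scatter), placing it with 2-chlorophenyl at the high end of these four compounds. No measurement at hand accounts for these differences.

Open, as far as these compounds go, is how an unsubstituted phenyl or a carboxylic acid on this ring would read. Also open, from the compounds shown here alone, is whether a longer chain would keep this order.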